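Trading the six-membered ring for a five-membered one

The compounds below may be only part of what the source reports. "The series", "measured", "known", "first", "only" and "open" are said of these compounds alone.

In a functional assay on NCI/ADR-RES cells (Homo sapiens) for antiproliferative activity (on this read-out lower numbers stand for stronger inhibition of growth and higher numbers for weaker inhibition of growth), compound 1 `CC/C=C\[C@H](C)[C@H](OC(N)=O)[C@@H](C)[C@H](O)[C@@H](C)C/C(C)=C\[C@H](C)[C@@H](O)[C@@H](C)/C=C\[C@@H](O)C[C@H](O)[C@H](C)CO` gives 10000 nM and compound 2 `CC/C=C\[C@H](C)[C@H](OC(N)=O)[C@@H](C)[C@H](O)[C@@H](C)C/C(C)=C\[C@H](C)[C@@H](O)[C@@H](C)/C=C\[C@@H](O)C[C@@H]1OC(=O)[C@H](C)C[C@H]1C` gives 140 nM, the lower of the two numbers. Compound 3 `CC/C=C\[C@H](C)[C@H](OC(N)=O)[C@@H](C)[C@H](O)[C@@H](C)C/C(C)=C\[C@H](C)[C@@H](O)[C@@H](C)/C=C\[C@@H](O)C[C@H]1CCC(=O)O1` departs from compound 2 by a group of 6 heavy atoms (4 carbon, 2 oxygen; one five-membered non-aromatic ring with 1 hetero atom) in place of a group of 9 heavy atoms (7 carbon, 2 oxygen; one six-membered non-aromatic ring with 1 hetero atom), on a saturated chain carbon, two bonds along the chain from a double-bonded chain carbon and an oxygen on a saturated carbon. For the measured compounds named here, the only measured step that bears on this place is a 71-fold lower number from compound 1 to compound 2 (1.85 log units; beyond the scatter), large and beyond the scatter, and it came with the six-membered ring replacing a group with no ring. Compound 3 keeps a ring, so a smaller move to a higher number is expected, beyond the scatter. The expected change is a 7.1-fold higher number from compound 2 to compound 3 (0.85 log units; beyond the scatter). For compound 3 the estimated value is 1000 nM, within an expected range of 200 nM to 6000 nM.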

Compound 3, concentration for 50% growth inhibition: 730 nM
The estimate for compound 3 lay 1.4-fold (0.14 log units) above the measured number, within the range that was stated.
By their numbers in this assay, from the lowest: compound 2; then compound 3; then compound 1.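

In this assay, a ring at this place still gives most of the gain over the open chain, a 14-fold lower number from compound 1 to compound 3 (1.14 log units; beyond the scatter), but the five-membered ring does not hold all of what the six-membered ring reached, a 5.2-fold higher number from compound 2 to compound 3 (0.72 log units; beyond the scatter). Having a ring is thus not enough to match compound 2; the kind of ring matters too. Nothing available explains the gap between the two rings.

The compounds shown do not separate ring size from the drop from 3 defined stereocentres to 1. They also leave open how a lactam, with nitrogen in place of the ring oxygen, would fare at this place.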